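Biaryl tail variation in a citrate-type series

The compounds below may be only part of what the source reports. "The series", "measured", "known", "first", "only" and "open" are said of these compounds alone.

Three measured compounds share a dicarboxylic acid head with a hydroxylated chain ending in a dichlorophenyl group. Compound 1, `O=C(O)C[C@](O)(C(=O)O)[C@@H](O)CCCCCCCc1ccc(Cl)cc1Cl`, carries a plain dichlorophenyl on a longer chain; in an assay on isolated protein for inhibition of ATP-citrate synthase (Homo sapiens) (on this read-out lower numbers stand for stronger inhibition and higher numbers for weaker inhibition), compound 1 gives 5700 nM. Compound 2, `O=C(O)[C@H](O)[C@@](O)(C[C@H](O)CCCCCCc1ccc(Cl)cc1Cl)C(=O)O`, with a hydroxyl on the head and the shorter chain, gives in this assay 550 nM. Compound 3, `O=C(O)C[C@@](O)(C[C@H](O)CCCCCCc1ccc(Cl)cc1-c1ccc(F)cc1)C(=O)O`, replaces one chlorine of the aromatic ring by a 4-fluorophenyl; in this assay compound 3 gives 2700 nM. On these numbers compound 3 stands second highest of the three: the number of compound 1 lies above it, beyond the scatter, and the number of compound 2 lies below it, further beyond the scatter.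

Compound 4, `Cc1ccc(-c2cc(Cl)ccc2CCCCCC[C@@H](O)C[C@](O)(CC(=O)O)C(=O)O)cc1`, differs from compound 3 in one place: methyl in place of fluoro on an aromatic carbon, which read one bond further out is 4-fluorophenyl to 4-methylphenyl. Among the compounds with values here, no measured pair in this set reports such a step, so no size can be taken from the data. Swapping one single heavy atom on the outer ring for another of the same size is expected to leave the number within the scatter, with no clear direction; the step from compound 3 to compound 4 is estimated as a 1.1-fold lower number from compound 3 to compound 4 (0.03 log units; within the scatter). In this assay compound 4 is therefore expected at about 2500 nM, within a range from 1000 nM to 6500 nM.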

Compound 4, inhibition constant: 2700 nM
The estimate for compound 4 lay 1.1-fold (0.03 log units) below the measured number; measured number inside the range.
By their numbers in this assay, from the lowest: compound 2; then compounds 3 and 4 (each within the scatter of the next); then compound 1.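

Methyl in place of fluoro on an aromatic carbon, para to a large group, reads in this assay as no change at the digits printed from compound 3 to compound 4 (within the scatter) and gives the first pair in this set that differs in one place. The earlier compounds shown here differ from each other in several places at once and could say nothing about this position taken alone; here, 4-fluorophenyl and 4-methylphenyl cannot be told apart on this read-out, so the two groups are interchangeable at this position as far as these two compounds go. Nothing at hand bears on a reason for this result.

Within the data shown here, whether the same holds for an amine or a carboxylic acid on that aromatic carbon remains open, since fluoro and methyl are the only two groups seen there and neither carries a hydrogen-bond donor or acceptor. Also open, on these data alone, is how a longer chain or an added hydroxyl on the head would act with the biaryl tail, since compounds 1 and 2 differ from compounds 3 and 4 in more than one place and give no separate reading of either change.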